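Sulfamoyl adenosine series: branched to sulfur-bearing side chain

A few compounds are considered here, and "the series" means these few. Any claim that something is new, unique, unknown or untested is made for them only; others in the source may bear on it.

Measured compounds:
compound 1 `CC(C)C[C@H](N)C(=O)NS(=O)(=O)OC[C@H]1O[C@@H](n2cnc3c(N)ncnc32)[C@H](O)[C@@H]1O` – 1100 nM
compound 2 `Nc1ncnc2c1ncn2[C@@H]1CO[C@H](COS(=O)(=O)NC(=O)[C@@H]2CCCN2)[C@@H](O)[C@H]1O` – 750 nM
compound 3 `CCC[C@H](N)C(=O)NS(=O)(=O)OC[C@H]1O[C@@H](n2cnc3c(N)ncnc32)[C@H](O)[C@@H]1O` – 4700 nM

In a functional assay on PBMC cells (Homo sapiens) for inhibition (a lower number here means a stronger inhibitor, a higher number a weaker inhibitor), compound 1 gives 1100 nM, the second highest of the three numbers. The nearest neighbour is compound 2, whose value lies within the scatter of compound 1, so no order between them is claimed. The furthest is compound 3, reached by a 4.3-fold higher number from compound 1 to compound 3 (0.63 log units; beyond the scatter), a hydrogen in place of methyl on a saturated chain carbon bound to two saturated chain carbons.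

Compound 4 `CSCC[C@H](N)C(=O)NS(=O)(=O)OC[C@H]1O[C@@H](n2cnc3c(N)ncnc32)[C@H](O)[C@@H]1O` differs from compound 1 by (methylsulfanyl)methyl in place of isopropyl on a saturated chain carbon, two bonds along the chain from an amine nitrogen and a carbonyl carbon. Among the measured compounds shown here, the only measured step touching this side chain is the one from compound 1 to compound 3, which shows that shortening the chain by one carbon costs potency. For the measured compounds named here, the change to compound 4 keeps the same number of heavy atoms but exchanges a branch for a straight chain with one sulfur, a change with no measured precedent in this set. The expectation is therefore a modest loss, a 2.3-fold higher number from compound 1 to compound 4 (0.36 log units; beyond the scatter), with wide uncertainty. Compound 4 is estimated at 2500 nM, range 700 nM to 9000 nM.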

Compound 4, half-maximal inhibitory concentration: 500 nM
Estimate against measurement, compound 4: 5.0-fold (0.70 log units) above; measured number outside the range, below it.
By their numbers in this assay, from the lowest: compounds 4, 2 and 1 (each within the scatter of the next, the first and the last beyond it); then compound 3.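

In this assay, the branched isobutyl side chain of compound 1 can give way to the unbranched 2-(methylsulfanyl)ethyl chain of compound 4 with a gain (a 2.2-fold lower number from compound 1 to compound 4 (0.34 log units; beyond the scatter)). The earlier step at this position showed only a loss, whereas methylsulfanyl in place of methyl at the end of the unbranched chain recovers far more (a 9.4-fold lower number from compound 3 to compound 4 (0.97 log units; beyond the scatter)), so an unbranched chain is not weak in itself and the group at its end strongly shifts the number. No measured evidence is available to explain either step.

The compounds shown leave open whether the sulfur matters or only the chain length, which an all-carbon n-butyl chain would separate. Also open, going by these compounds, is how a longer chain, such as 2-(ethylsulfanyl)ethyl, or the matching sulfone would fare at this position.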